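Methoxy in Place of Methyl on the Anilino Ring

The source may report more compounds than this note shows. Statements on the series, on what has been measured and on what is new or still open speak of the compounds shown alone.

Measured compounds in a functional assay on MGC-803 cells (Homo sapiens) for inhibition, read by MTT assay, with a stated time of 72 h; a higher number here means a weaker inhibitor, a lower number a stronger inhibitor:
compound 1, `CC(C)c1ccc(-c2nc(SCc3cn(CC(=O)NC(=O)Nc4ccccn4)nn3)nc(Nc3cccc(C(F)(F)F)c3)c2C#N)cc1`, > 64000 nM
compound 2, `Cc1ccccc1Nc1nc(SCc2cn(CC(=O)NC(=O)Nc3ccccn3)nn2)nc(-c2ccc(C(C)C)cc2)c1C#N`, 19000 nM

Compound 1 reaches only a limit of the assay in this assay, giving > 64000 nM. Among the compounds with values here, compound 2, in which a 2-methylphenyl replaces the 3-(trifluoromethyl)phenyl on the nitrogen of the shared core, is the only compound with a numbered value, giving 19000 nM. Within the data shown here, that single change is the only measured step: an at least 3.3-fold lower number from compound 1 to compound 2 (0.52 log units; beyond the scatter), with the starting point resting on (the limit of > 64000 nM in this assay, at which 1 of the 2 values shown sits).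

Compound 3, `COc1ccccc1Nc1nc(SCc2cn(CC(=O)NC(=O)Nc3ccccn3)nn2)nc(-c2ccc(C(C)C)cc2)c1C#N`, keeps the whole core of compound 2 and alters one small group: methoxy in place of methyl on an aromatic carbon. Among the measured compounds shown here, no measured step exchanges one small substituent for another on that ring, so the only guidance is the step from compound 1 to compound 2, which was at least modest when a whole different aryl entered. A methyl-to-methoxy swap is far smaller, so no step beyond the scatter is expected in this assay. The expected step is no change at the digits printed from compound 2 to compound 3 (within the scatter). Compound 3 is therefore estimated to give 19000 nM, within 6000 nM to 60000 nM.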

Compound 3, half-maximal inhibitory concentration: > 64000 nM
Compound 3 ended at the assay's limit; the forecaster's own chance of this, stated with the estimate: 20%; middle value at least 3.3-fold (0.52 log units) away from the limit.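

In this assay, methoxy in place of methyl on an aromatic carbon, ortho to a large group, gives an at least 3.3-fold higher number from compound 2 to compound 3 (0.52 log units; beyond the scatter). The earlier compounds shown here showed a step only when a whole different aryl group entered, whereas here the exchange of one small group for another on the same ring is enough to move the result beyond the scatter. Compound 3 gives > 64000 nM, which is a limit of the assay and not a number, so the step shows a minimum size only, and the step between compound 1 and compound 3 cannot be read, leaving compound 2 as the only compound with a numbered value: the limit of > 64000 nM in this assay, at which 2 of the 3 values shown sit.

Only methyl and methoxy can be compared at this carbon, so the compounds shown do not tell whether the difference follows from the oxygen or from some other feature of the methoxy group. From the compounds shown here alone, what a chlorine, an ethyl, a hydroxy or an amine would give at the same carbon stays open, as does whether any of them would give a lower number than compound 2.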